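Methoxy to fluoro: estimating a half-life

The compounds below may be only part of what the source reports. "The series", "measured", "known", "first", "only" and "open" are said of these compounds alone.

Compound 1 `Cc1ccccc1-c1cccc(-c2cc3nc(C)c([C@H](OC(C)(C)C)C(=O)O)c(-c4cc(F)c5c(c4C)CCCO5)n3n2)c1` gives 4.1 h
Compound 2 `COc1ccccc1-c1cccc(-c2cc3nc(C)c([C@H](OC(C)(C)C)C(=O)O)c(-c4cc(F)c5c(c4C)CCCO5)n3n2)c1` gives 3 h

Among the compounds with values here, in an ADME assay on the whole organism (Rattus norvegicus, strain Sprague-Dawley) for metabolic stability, read by LC-MS, with a stated time of 10 min (a lower number here means that the compound disappears faster, a higher number that the compound lasts longer), compound 2 gives 3 h and lies within the scatter of compound 1, the only other measured compound. Compound 3 `Cc1nc2cc(-c3cccc(-c4ccccc4F)c3)nn2c(-c2cc(F)c3c(c2C)CCCO3)c1[C@H](OC(C)(C)C)C(=O)O` has not yet been measured. It differs from compound 2 by fluoro in place of methoxy on an aromatic carbon, ortho to a large group, which turns 2-methoxyphenyl into 2-fluorophenyl fluoro in place of methoxy on an aromatic carbon in an otherwise unchanged structure. Within the data shown here, the only measured step bearing on this is a 1.4-fold lower number from compound 1 to compound 2 (0.14 log units; within the scatter) and it involves the same aromatic carbon, though no measured compound carries fluoro there. Only a change within the scatter is therefore expected, and the estimated step is a 1.2-fold higher number from compound 2 to compound 3 (0.07 log units; within the scatter) in a direction that remains uncertain. For compound 3 the estimated half-life is 3.5 h with 1.8 h to 6.5 h as the expected range.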

Compound 3, half-life: 2 h
Beside the measured number, compound 3's estimate is 1.8-fold (0.24 log units) above it; measured number inside the range.
By their numbers in this assay, from the lowest: compounds 3, 2 and 1 (each within the scatter of the next, the first and the last beyond it).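

In this assay, within the data shown here, this aromatic carbon now carries three different groups, and fluoro in place of methyl gives the only step so far that lies beyond the scatter, a modest one: a 2.1-fold lower number from compound 1 to compound 3 (0.31 log units; beyond the scatter). Fluoro in place of methoxy gives a 1.5-fold lower number from compound 2 to compound 3 (0.18 log units; within the scatter), so these two groups cannot be told apart here, and methoxy stays within the scatter of both methyl and fluoro. Nothing available explains why the half-life follows these groups as it does.

From the compounds shown here alone, whether chloro, an amine or a longer chain such as ethoxy on this carbon would fall within the same narrow span remains open. So does whether the step from methyl to fluoro would hold on a core other than the one shared by these three compounds.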